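Carbamate versus urea on the anilide nitrogen of the biaryl core

The source may hold more compounds than are shown below. What is called first, only, known or untested is meant among the compounds shown, and "the series" means these compounds.

Compound 2 `CN(C)C(=O)N(C)c1cccc(-c2ccc(N(C)C)cc2)c1` has the lower of the two numbers measured in an assay on COS-7 cells for inhibition of patatin-like phospholipase domain-containing protein 2 (Mus musculus), tested at 200 uM; a lower number here means less inhibition, a higher number more inhibition at the concentration tested (going by the name of the read-out): compound 2 gives 74%, while compound 1 `CCOC(=O)Nc1cccc(-c2ccc(N(C)C)cc2)c1` gives 93%. For the measured compounds named here, the single measured step, a number 19 percentage points lower from compound 1 to compound 2 (beyond the scatter), swaps the (ethoxycarbonyl)amino group of compound 1 for the (dimethylcarbamoyl)(methyl)amino group of compound 2 in one move, so it mixes two alterations: methylation of the nitrogen and dimethylcarbamoyl in place of ethoxycarbonyl.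

Compound 3 `CCOC(=O)N(C)c1cccc(-c2ccc(N(C)C)cc2)c1` takes only one of those back. It differs from compound 2 by ethoxy in place of dimethylamino on a carbonyl carbon, that is dimethylcarbamoyl to ethoxycarbonyl on the (ethoxycarbonyl)(methyl)amino group, while the methyl on the nitrogen stays. The step from compound 1 to compound 2 is the only one that bears on this, and it cannot say how much of its loss came from the carbonyl substituent rather than from the nitrogen methyl. Taking the carbonyl change as part of it, compound 3 is expected to recover part of the difference, a step of a number 10 percentage points higher from compound 2 to compound 3 (within the scatter) in this assay. The estimate for compound 3 is therefore 84%, with a range from 68% to 95%.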

Compound 3, a percentage reported as inhibition, at one concentration (the size of the read-out at that concentration, not a potency): 20%
The estimate for compound 3 lay 64 percentage points above the measured number; measured number outside the range, below it.
By their numbers in this assay, from the lowest: compound 3; then compound 2; then compound 1.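

Compound 3 isolates the nitrogen methyl: in this assay, methyl in place of hydrogen on the amide-type nitrogen of the ethoxycarbonyl compound gives a number 73 percentage points lower from compound 1 to compound 3 (beyond the scatter) and so accounts for a large loss on its own. With that methyl held constant, ethoxy in place of dimethylamino on the carbonyl carbon gives a number 54 percentage points lower from compound 2 to compound 3 (beyond the scatter) and shows that dimethylcarbamoyl retains much more of the read-out than ethoxycarbonyl on the methylated nitrogen. The two alterations therefore do not simply add, since the combined change gives only a number 19 percentage points lower from compound 1 to compound 2 (beyond the scatter) and the size of the nitrogen methyl step depends on the carbonyl substituent, although no data shown give a reason for this.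

The compounds shown pair dimethylcarbamoyl only with the methylated nitrogen, so the effect of that methyl on the urea remains open. Also open, as far as these compounds go, is how a longer chain on that nitrogen, such as ethyl, or a ring-closed carbonyl substituent, such as pyrrolidine-1-carbonyl, would read in this assay at this single concentration.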